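This account rests on a few compounds, and the source may have more. Where it says the series, first, only, none or still open, it means among the compounds named here.

Three compounds from the same family have so far been run in an ADME assay on PC-3 cells (Homo sapiens) for cytotoxicity, read by CCK-8 assay, with a stated time of 6 days; a higher number here means a weaker inhibitor, a lower number a stronger inhibitor. Compound 1 `CC(O)c1ccc(C(=O)N[C@@H](C)Cn2ccc(-c3ccc(C#N)c(Cl)c3)n2)cc1` gives > 30000 nM in this assay, a value that is a limit of the assay rather than a measured number. Compound 2 `C[C@@H](Cn1ccc(-c2ccc(C#N)c(Cl)c2)n1)NC(=O)c1cccc(OCC(O)CO)c1` likewise reaches only > 30000 nM in this assay, again a limit. Compound 3 `CC(Cn1ccc(-c2ccc(C#N)c(Cl)c2)n1)C(=O)Nc1cc[nH]n1` stands at > 30000 nM in this assay, also a limit and not a number. For the measured compounds named here, compound 3 therefore cannot be ranked against the other two: all three sit at the same boundary, as the limit of > 30000 nM in this assay, at which 3 of the 3 values shown sit, records, and no step between any pair of them can be sized.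

Compound 4 `CC(=O)c1cccc(NC(=O)C(C)Cn2ccc(-c3ccc(C#N)c(Cl)c3)n2)c1` is the next member to be tested. It differs from compound 3 in one place: 3-acetylphenyl in place of 1H-pyrazol-3-yl on an amide-type nitrogen. Going by the values given here, every value so far is a limit. Among the compounds with values here, there is no measured step that could point to a direction for this change. The expected step is a number no higher from compound 3 to compound 4 (the limit leaves the size open), meaning no movement beyond the usual scatter. Compound 4 is therefore expected to give about 30000 nM in this assay, within a range from 15000 nM to 60000 nM, and most likely once more only a limit rather than a number.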

Compound 4, half-maximal inhibitory concentration: > 30000 nM
Compound 4: only a limit was reported (the forecaster's own chance of this, stated with the estimate: 85%); the middle value sits exactly at the limit.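

In this assay compound 4 gives > 30000 nM, which is a limit and not a number. Compound 3 also stands at a limit, so no step between compound 3 and compound 4 can be read, and the family stays at one boundary: the limit of > 30000 nM in this assay, at which 4 of the 4 values shown sit.

The compounds shown leave open how 3-acetylphenyl and 1H-pyrazol-3-yl compare, and whether any member would give a measurable number in this assay.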